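Swapping a Thiophene for a Pyridine on the Shared Core

A few compounds are considered here, and "the series" means these few. Any claim that something is new, unique, unknown or untested is made for them only; others in the source may bear on it.

Three compounds built on one shared core were tested in an assay on isolated protein for inhibition of DNA topoisomerase 1 (Homo sapiens), with a stated time of 30 min, tested at 100 uM; a higher number here means a stronger effect of the compound at the concentration tested, a lower number a weaker effect. Compound 1 `Oc1cccc(-c2cc(-c3ccc(Cl)cc3)nc(-c3cccs3)c2)c1` gives 15.1%. Compound 2 `Oc1ccc(-c2cc(-c3ccccc3)nc(-c3ccccc3Cl)c2)cc1` gives 13.6%, and compound 3 `Oc1cccc(-c2cc(-c3cccc(Cl)c3)nc(-c3cccs3)c2)c1` gives 7.6%. Compound 1 holds the highest of the three numbers, but its gaps to compound 2 and to compound 3 both lie within the usual scatter, so no real order among the three can be claimed. For the measured compounds named here, the only single-point step among the measured compounds, a number 7.5 percentage points lower from compound 1 to compound 3 (within the scatter), swaps one chlorophenyl group for another and stays within the scatter.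

Compound 4 `Oc1cccc(-c2cc(-c3ccncc3)nc(-c3ccc(Cl)cc3)c2)c1` has not yet been measured. It differs from compound 1 in one place: pyridin-4-yl in place of thiophen-2-yl on an aromatic carbon. Going by the values given here, no measured step touches this group; the one known step concerns a different group and was itself within the scatter. There is thus no basis to expect a shift beyond the scatter in this assay in either direction. Compound 4 is expected to give about 13%, within a range from 3% to 25%. That estimate means a step of a number 2.1 percentage points lower from compound 1 to compound 4 (within the scatter), expected to fall within the scatter.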

Compound 4, a percentage reported as inhibition, at one concentration (the size of the read-out at that concentration, not a potency): 8%
Compound 4: the middle estimate sits 5 percentage points above what was measured; low and high end bracket the measured number.
By their numbers in this assay, from the lowest: compounds 3, 4, 2 and 1 (each within the scatter of the next).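

For the compounds shown here, at the position next to the ring nitrogen, the step of a number 7.1 percentage points lower from compound 1 to compound 4 (within the scatter) in this assay is the first measured change of thiophen-2-yl, here to pyridin-4-yl. A five-membered aromatic ring with a sulfur thus gives way to a six-membered aromatic ring with a nitrogen without a shift that can be told from the scatter, so this single change shows no measurable effect on the read-out at the one concentration tested. No measured information bears on what lies behind this result.

On these data alone, what remains open is whether a different kind of group at this position, such as an open-chain amine, a morpholine or a carboxylic acid, would give a step beyond the scatter. The compounds shown also leave open whether pyridin-3-yl would behave like pyridin-4-yl.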